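Aryl versus cyclohexyl on the enone chain carbon

The compounds below may be only part of what the source reports. "The series", "measured", "known", "first", "only" and "open" are said of these compounds alone.

Measured so far:
compound 1 `COc1ccc(C(=O)/C(=C/c2ccc(Cl)cc2Cl)CCOC(C)=O)cc1`: 34800 nM in a functional assay on NB-4 cells (Homo sapiens) for inhibition, read by XTT assay, with a stated time of 48 h; a higher number here means a weaker inhibitor, a lower number a stronger inhibitor
compound 2 `COc1ccc(C(=O)/C(=C/C2CCCCC2)CCOC(C)=O)cc1`: > 100000 nM in this assay, a limit of the assay

Compound 2 stands only at the edge of the numbers: in this assay compound 2 gives > 100000 nM, which is a limit and not a number (the limit of > 100000 nM in this assay, at which 1 of the 2 values shown sits). Compound 3 `COc1ccc(C(=O)/C(=C/c2ccc([N+](=O)[O-])cc2)CCOC(C)=O)cc1` carries 4-nitrophenyl in place of cyclohexyl on a double-bonded chain carbon bound to a double-bonded chain carbon. Going by the values given here, the one measured step that bears on it is an at least 2.8-fold higher number from compound 1 to compound 2 (0.45 log units; beyond the scatter), where an aromatic ring gave way to cyclohexyl and the number rose. Restoring an aromatic ring is expected to reverse that. Compound 3 is therefore expected to show an at least 2.5-fold lower number from compound 2 to compound 3 (0.39 log units; beyond the scatter). Compound 3 is estimated at 40000 nM, within 12000 nM to 120000 nM.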

Compound 3, half-maximal inhibitory concentration: > 100000 nM
Compound 3: a limit, no number (the forecaster's own chance of this, stated with the estimate: 30%); middle value at least 2.5-fold (0.39 log units) from the limit.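

An aromatic ring at this position does not by itself give a readable number in this assay: 4-nitrophenyl in place of 2,4-dichlorophenyl gives an at least 2.8-fold higher number from compound 1 to compound 3 (0.45 log units; beyond the scatter). Compound 3 gives > 100000 nM, which is a limit of the assay. Compound 2 and compound 3 sit at the same limit, so the step between them cannot be read: the limit of > 100000 nM in this assay, at which 2 of the 3 values shown sit.

As far as these compounds go, it remains open whether the number in compound 1 depends on both chlorine atoms or on one. Unsubstituted phenyl, 4-chlorophenyl and 4-aminophenyl at this position would help separate these readings.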